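Amide variations on a shared core

The compounds below may be only part of what the source reports. "The series", "measured", "known", "first", "only" and "open" are said of these compounds alone.

Compound 1 `C=CC(=O)Nc1cccc(-c2nc3ccccc3s2)c1`, compound 2 `C=C(C)C(=O)Nc1cccc(-c2nc3ccccc3s2)c1` and compound 3 `O=C(O)/C=C/C(=O)Nc1cccc(-c2nc3ccccc3s2)c1` share one core and differ only in the group on the carbonyl carbon. In an ADME assay on Raji cells (Homo sapiens) for inhibition, with a stated time of 72 h (on this read-out lower numbers stand for an effect already at smaller amounts and higher numbers for an effect only at larger amounts of compound), compound 1 reaches only the assay limit, > 25000 nM. Compound 2 likewise gives a limit, > 25000 nM. Compound 3 also stands at a limit, > 25000 nM. All three values sit at the limit of > 25000 nM in this assay, at which 3 of the 3 values shown sit, so the steps a step that the two limits leave unreadable from compound 1 to compound 2, a step that the two limits leave unreadable from compound 1 to compound 3 and a step that the two limits leave unreadable from compound 2 to compound 3 give no size. Compound 4 `CN(C)CCC(=O)Nc1cccc(-c2nc3ccccc3s2)c1` carries 2-(dimethylamino)ethyl in place of 2-carboxyethenyl on a carbonyl carbon. Among the compounds with values here, no measured step bears on this change, and no direction beyond the scatter can be read. Compound 4 is expected at 30000 nM, within 8000 nM to 100000 nM, most probably again a limit. The expected step that the limit leaves unreadable from compound 3 to compound 4 is thus no step beyond the scatter.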

Compound 4, half-maximal effective concentration: > 25000 nM
Compound 4 gave a limit, no number (the forecaster's own chance of this, stated with the estimate: 75%); the middle value is on the limit's open side.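

No step from compound 1, compound 2 or compound 3 to compound 4 can be read, since each value is a limit: the limit of > 25000 nM in this assay, at which 4 of the 4 values shown sit.

The compounds shown leave open which group on the carbonyl carbon, if any, gives a numerical value in this assay.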